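The source may report more compounds than this note shows. Statements on the series, on what has been measured and on what is new or still open speak of the compounds shown alone.

Measured so far in the series:

compound 1 `COc1cc(/C=C/C=C/C(=O)N2CCCCC2)cc(OC)c1O` — 32.7%
compound 2 `O=C(/C=C/C=C/c1ccc(O)cc1)N1CCCCC1` — 44.4%

Both were run in an assay for inhibition of Polyunsaturated fatty acid 5-lipoxygenase (Homo sapiens), read by spectrophotometry, tested at 20 uM; a higher number here means more inhibition at the concentration tested (going by the name of the read-out), a lower number less inhibition. Compound 2 stands highest of the two numbers shown; its nearest neighbour is compound 1, whose reading in this assay lies lower by a gap beyond the usual scatter. Among the measured compounds shown here, the two differ in more than one place, so no single step between them is worked out; the values alone say that the compound with the bare hydroxyphenyl end reads higher than the one carrying methoxy groups as well.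

The next compound, compound 3 `COc1cc(/C=C/C=C/C(=O)N2CCCCC2)ccc1O`, is to be measured in this assay. It differs from compound 2 by methoxy in place of hydrogen on an aromatic carbon.

For the measured compounds named here, no step of this exact kind is on record. Compound 1, which also carries methoxy on the ring, gives 32.7%, and on that basis a downward shift is expected, of a size near the edge of the scatter, so a number 6.4 percentage points lower from compound 2 to compound 3 (within the scatter) is the expected step from compound 2 to compound 3. Compound 3 is therefore estimated at 38%, with a range from 27% to 50%.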

Compound 3, a percentage reported as inhibition, at one concentration (the size of the read-out at that concentration, not a potency): 55.5%
Beside the measured number, compound 3's estimate is 17.5 percentage points below it; measured number outside the range, above it.
By their numbers in this assay, from the lowest: compound 1; then compound 2; then compound 3.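

In this assay, methoxy in place of hydrogen on an aromatic carbon, ortho to a hydroxy group, gives a number 11.1 percentage points higher from compound 2 to compound 3 (beyond the scatter) and so shows that a methoxy on this ring does not by itself lower the reading, a point compound 1 alone could not settle. Hydrogen in place of methoxy on an aromatic carbon gives a number 22.8 percentage points higher from compound 1 to compound 3 (beyond the scatter), so the step to a single methoxy and the step away from a second one both end at the highest of the three readings, and the effect of methoxy on this ring depends on whether another methoxy is present. Nothing on record bears on why the readings fall in this order.

Still open, going by these compounds, is whether the rise belongs to methoxy in particular or would also come with ethoxy, a chlorine atom or an amine on the same aromatic carbon. Also open, on these data alone, is whether the hydroxy group is needed for the rise, which a compound with a second methoxy in its place would test, and whether the order of these readings would hold as potencies, since each one is taken at a single concentration.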